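Swapping methylsulfonyl for methoxycarbonyl in compound 2

A few compounds are considered here, and "the series" means these few. Any claim that something is new, unique, unknown or untested is made for them only; others in the source may bear on it.

Values so far in an ADME assay on SK-N-BE(2)-M17 cells (Homo sapiens) for cytotoxicity; on this read-out higher numbers stand for lower toxicity in this test and lower numbers for higher toxicity in this test
- Compound 1 `CC1=CC(C)(C)Nc2c(C(=O)NC/C=C/S(C)(=O)=O)cccc21` gives 19600 nM
- Compound 2 `C[C@@H]1CC(C)(C)Nc2c(C(=O)NC/C=C/S(C)(=O)=O)cccc21` gives > 25000 nM (a limit, not a number)
- Compound 3 `COC(=O)/C=C/CNC(=O)c1cccc2c1NC(C)(C)C=C2C` gives 18100 nM

Compound 2 sits at the limit of > 25000 nM in this assay, at which 1 of the 3 values shown sits, and so has no exact number. Compound 4 `COC(=O)/C=C/CNC(=O)c1cccc2c1NC(C)(C)C[C@H]2C` is not yet measured and differs from compound 2 by methoxycarbonyl in place of methylsulfonyl on a double-bonded chain carbon bound to a double-bonded chain carbon in one place: methoxycarbonyl in place of methylsulfonyl on a double-bonded chain carbon bound to a double-bonded chain carbon. Going by the values given here, one measured step bears on this swap, a 1.1-fold lower number from compound 1 to compound 3 (0.03 log units; within the scatter), and it stays within the scatter. No step beyond the scatter is therefore expected in this assay. The expected step is a step that the limit leaves unreadable from compound 2 to compound 4 and is only an estimate resting on that single pair. For compound 4 the estimated value is 27000 nM, with an expected range from 16000 nM to 45000 nM in this read-out.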

Compound 4, half-maximal cytotoxic concentration: 11000 nM
Compound 4: middle estimate off by 2.5-fold (0.39 log units), on the high side, outside the stated range (below it).
By their numbers in this assay, from the lowest: compounds 4, 3 and 1 (each within the scatter of the next). At a limit, above all of these: compound 2.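

In this assay, methoxycarbonyl in place of methylsulfonyl now gives a step beyond the scatter, an at least 2.2-fold lower number from compound 2 to compound 4 (0.35 log units; beyond the scatter), so this change on a double-bonded chain carbon is not always silent. For compound 2, > 25000 nM is a limit, not a number. Whether the change acts differently on the two cores remains unsettled: the same change on two cores in this assay, a 1.1-fold lower number (0.03 log units; within the scatter) from compound 1 to compound 3 and an at least 2.2-fold lower number (0.35 log units; beyond the scatter) from compound 2 to compound 4; the limit leaves it open whether they differ

The compounds shown leave open how a nitrile or a carboxylic acid would read at this place. An exact number for compound 2 would also be needed to settle the size of this step.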